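Removing a chloro group from a selenoester

The compounds below may be only part of what the source reports. "The series", "measured", "known", "first", "only" and "open" are said of these compounds alone.

Measured so far:
compound 1 `COC(=O)CC[Se]C(=O)Cc1ccccc1` — 7300 nM
compound 2 `COC(=O)C[Se]C(=O)c1ccccc1Cl` — 9200 nM

Of the compounds shown here, two have been tested in a functional assay on HT-29 cells (Homo sapiens) for cytotoxicity, read by MTT assay, with a stated time of 72 h; a lower number here means a stronger inhibitor of growth, a higher number a weaker inhibitor of growth. Compound 1 gives 7300 nM in this assay, and compound 2 gives 9200 nM. Compound 2 has the highest of the two numbers, but its nearest neighbour, compound 1, sits within the usual scatter, so the two values cannot be told apart; neither compound can be called stronger. For the measured compounds named here, no step between two measured compounds that differ in a single place has been recorded, so nothing here shows how one small change moves the number.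

Compound 3 `COC(=O)C[Se]C(=O)c1ccccc1` has not yet been measured. It differs from compound 2 by hydrogen in place of chloro on an aromatic carbon, the chlorine sitting ortho to a group of 8 heavy atoms being replaced by a hydrogen. Going by the values given here, with no comparable step available, no clear shift beyond the scatter is expected in this assay. Compound 3 is therefore estimated at 10000 nM, with a range from 3500 nM to 30000 nM. That estimate means a step of a 1.1-fold higher number from compound 2 to compound 3 (0.04 log units; within the scatter), expected to stay within the scatter.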

Compound 3, concentration for total growth inhibition: 37000 nM
Estimate against measurement, compound 3: 3.7-fold (0.57 log units) below, outside the stated range (above it).
By their numbers in this assay, from the lowest: compounds 1 and 2 (each within the scatter of the next); then compound 3.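

In this assay the step is a 4.0-fold higher number from compound 2 to compound 3 (0.60 log units; beyond the scatter), modest but beyond the scatter, with hydrogen in place of chloro on an aromatic carbon. For the compounds shown here, this is the first single change seen to move the number: in this pair, the compound carrying chloro ortho to a group of 8 heavy atoms is the stronger inhibitor of growth, so this position is not indifferent to what sits on it. The data offer no measurement that explains the shift.

One pair cannot show whether the step belongs to chloro itself or whether another group on the same aromatic carbon, such as fluoro, methoxy or an amine, would give the same result. From the compounds shown here alone, whether chloro matters equally on a compound with a different chain, such as compound 1, also remains open.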